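From a bromofluorophenyl to a chloronitrophenyl hydrazone

The source may hold more compounds than are shown below. What is called first, only, known or untested is meant among the compounds shown, and "the series" means these compounds.

Compound 1 `Cn1c(=O)c(=O)n(C2CCCC2)c2nc(N/N=C/c3ccccc3)ncc21`: in a functional assay on HCT-116 cells (Homo sapiens) for antiproliferative activity, read by MTT assay (a higher number here means a weaker inhibitor, a lower number a stronger inhibitor), compound 1 gives > 100000 nM, which is a limit of the assay.
Compound 2 `Cn1c(=O)c(=O)n(C2CCCC2)c2nc(N/N=C/c3cccs3)ncc21`: in this assay compound 2 gives 52600 nM.
Compound 3 `Cn1c(=O)c(=O)n(C2CCCC2)c2nc(N/N=C/c3ccc(F)cc3Br)ncc21`: in this assay compound 3 gives 8390 nM.

Compound 3 stands lowest of the two numbers reported in this assay; its nearest neighbour is compound 2, separated by a 6.3-fold lower number from compound 2 to compound 3 (0.80 log units; beyond the scatter). The value of compound 1 is only a limit (the limit of > 100000 nM in this assay, at which 1 of the 3 values shown sits). Compound 4 `Cn1c(=O)c(=O)n(C2CCCC2)c2nc(N/N=C/c3cc([N+](=O)[O-])ccc3Cl)ncc21` differs from compound 3 by 2-chloro-5-nitrophenyl in place of 2-bromo-4-fluorophenyl on a carbon with a double bond to nitrogen. For the measured compounds named here, no measured step exchanges one substituted phenyl for another on this carbon. Going by the values given here, the steps that bear on the place are an at least 11-fold lower number from compound 1 to compound 3 (1.07 log units; beyond the scatter), a 6.3-fold lower number from compound 2 to compound 3 (0.80 log units; beyond the scatter) and an at least 1.9-fold lower number from compound 1 to compound 2 (0.27 log units; that floor lies within the scatter), all of which favour the substituted phenyl of compound 3 over phenyl or thiophen-2-yl. Since compound 4 keeps a halogen-bearing phenyl on the same carbon, a step of roughly a 1.2-fold higher number from compound 3 to compound 4 (0.08 log units; within the scatter) is expected, that is no change beyond the scatter. The estimate for compound 4 in this assay is 10000 nM, with a range from 2500 nM to 40000 nM.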

Compound 4, half-maximal inhibitory concentration: 5610 nM
Compound 4: middle estimate off by 1.8-fold (0.25 log units), on the high side, and the stated range covers the measured number.
By their numbers in this assay, from the lowest: compounds 4 and 3 (each within the scatter of the next); then compound 2. At a limit, above all of these: compound 1.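

With two differently substituted phenyls now on the carbon with a double bond to nitrogen, the exchange of 2-bromo-4-fluorophenyl for 2-chloro-5-nitrophenyl gives a 1.5-fold lower number from compound 3 to compound 4 (0.17 log units; within the scatter) in this assay, so these two groups are not told apart here. The gain over the simpler groups is thus not confined to compound 3, with a 9.4-fold lower number from compound 2 to compound 4 (0.97 log units; beyond the scatter) and an at least 17-fold lower number from compound 1 to compound 4 (1.25 log units; beyond the scatter). The value of compound 1 is a limit of the assay, so that last step is only a floor: the limit of > 100000 nM in this assay, at which 1 of the 4 values shown sits.

On these data alone, compound 3 and compound 4 differ in all their ring substituents at once, so what each substituent contributes stays open. Also open, as far as these compounds go, is how a phenyl carrying only a chlorine, only a bromine, an amine or a carboxylic acid would compare.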